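The source may report more compounds than this note shows. Statements on the series, on what has been measured and on what is new or still open speak of the compounds shown alone.

Of the compounds shown here, three sharing one core have been measured in a functional assay on MCF7 cells (Homo sapiens) for cytotoxicity, read by WST assay, with a stated time of 72 h; on this read-out higher numbers stand for weaker inhibition and lower numbers for stronger inhibition. In this read-out, compound 1 `CCOc1ccc(C2(c3ccc(O)cc3)C(=O)Nc3c2ccc(F)c3F)cc1`, with 4-ethoxyphenyl on a saturated ring carbon, gives 11 nM. Compound 2 `O=C1Nc2c(ccc(F)c2F)C1(c1ccncc1)c1ccc(O)cc1`, with pyridin-4-yl in that place, gives 37 nM, and compound 3 `CCCCCC1(c2ccc(O)cc2)C(=O)Nc2c1ccc(F)c2F`, with pentyl there, gives 96 nM. Compound 3 therefore has the highest number of the three, meaning the weakest inhibition among them.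

Compound 4 `O=C1Nc2c(ccc(F)c2F)C1(c1ccc(O)cc1)C1CCCC1` differs from compound 3 in one place: cyclopentyl in place of pentyl on a saturated ring carbon. Cyclopentyl stands in place of pentyl on a saturated ring carbon, with the atom count unchanged. Going by the values given here, no measured step makes this exchange directly. The closest evidence is an 8.7-fold higher number from compound 1 to compound 3 (0.94 log units; beyond the scatter) and a 2.6-fold higher number from compound 2 to compound 3 (0.41 log units; beyond the scatter), both modest and beyond the scatter, and a 3.4-fold higher number from compound 1 to compound 2 (0.53 log units; beyond the scatter) shows that the two ring-bearing groups also differ from each other. Among these three compounds, both groups with a ring give lower numbers than pentyl, and none goes against this. However, neither of those rings is non-aromatic, so the inference is loose. A modest step to a lower number is expected in this assay, similar in size to the smaller pentyl step. The estimate amounts to an expected 2.3-fold lower number from compound 3 to compound 4 (0.36 log units; beyond the scatter). For compound 4, the expected value is 42 nM, with an estimated range from 14 nM to 125 nM.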

Compound 4, half-maximal inhibitory concentration: 12 nM
For compound 4 the middle estimate is 3.5-fold (0.54 log units) above the measured one, and the stated range ends above it.
By their numbers in this assay, from the lowest: compounds 1 and 4 (each within the scatter of the next); then compound 2; then compound 3.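

In this assay, going by these compounds alone, replacing the open pentyl chain with cyclopentyl, which has the same count of carbon atoms, gives an 8.0-fold lower number from compound 3 to compound 4 (0.90 log units; beyond the scatter) and so shows that a ring at this saturated ring carbon need not be aromatic to give a low number, something the earlier compounds, with only aromatic rings there, could not show. Putting cyclopentyl in place of pyridin-4-yl gives a 3.1-fold lower number from compound 2 to compound 4 (0.49 log units; beyond the scatter) as well, whereas putting it in place of 4-ethoxyphenyl gives a 1.1-fold higher number from compound 1 to compound 4 (0.04 log units; within the scatter) and thus leaves these two groups indistinguishable in this read-out, although one is a small non-aromatic ring of carbon only and the other an aromatic ring carrying an ether chain. No measurement is available that accounts for the gap between the open chain and the closed ring. The compounds shown leave open whether this result is particular to a five-membered ring, as a cyclobutyl or cyclohexyl group at the same carbon would test, or whether a branched chain such as isopropyl or tert-butyl would do as well. They also leave open how this assay would respond to a non-aromatic ring containing a heteroatom, such as tetrahydropyran-4-yl or piperidin-4-yl, in the place of cyclopentyl.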